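A methyl added to the benzyl arm of compound 3

A few compounds are considered here, and "the series" means these few. Any claim that something is new, unique, unknown or untested is made for them only; others in the source may bear on it.

Compound 1 `CCNCCCOc1ccc2cc(NC(=O)c3ccc(O)c(CC=C(C)C)c3)c(=O)oc2c1C` gives 720 nM in a functional assay on SK-BR-3 cells (Homo sapiens) for antiproliferative activity; on this read-out higher numbers stand for weaker inhibition and lower numbers for stronger inhibition. Compound 2 `CCCNCCCOc1ccc2cc(NC(=O)c3ccc(O)c(CC=C(C)C)c3)c(=O)oc2c1C` gives 990 nM in this assay, and compound 3 `CC(C)=CCc1cc(C(=O)Nc2cc3ccc(OCCCNCc4ccccc4)c(C)c3oc2=O)ccc1O` gives 470 nM. The difference between compound 1 and compound 2 is methyl in place of hydrogen on a saturated chain carbon, two bonds along the chain from an amine nitrogen, and it made a step of a 1.4-fold higher number from compound 1 to compound 2 (0.14 log units; within the scatter). The cores of compound 1 and compound 3 differ by phenyl in place of methyl on a saturated chain carbon bound to an amine nitrogen, with a step of a 1.5-fold lower number from compound 1 to compound 3 (0.19 log units; within the scatter); compound 2 and compound 3 differ by a 2.1-fold lower number from compound 2 to compound 3 (0.32 log units; beyond the scatter).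

Compound 4 `CC(C)=CCc1cc(C(=O)Nc2cc3ccc(OCCCN[C@H](C)c4ccccc4)c(C)c3oc2=O)ccc1O` is not yet measured. It differs from compound 3 by methyl in place of hydrogen on a saturated chain carbon bound to an amine nitrogen and an aromatic carbon. This is the same kind of change as that from compound 1 to compound 2, but the place is not the same: in the measured pair the methyl enters two bonds along the chain from an amine nitrogen, whereas in compound 4 it enters on a carbon bound to an amine nitrogen and an aromatic carbon. Because the measured step of a 1.4-fold higher number from compound 1 to compound 2 (0.14 log units; within the scatter) stayed within the scatter, compound 4 is expected to show a similarly small step of a 1.3-fold higher number from compound 3 to compound 4 (0.12 log units; within the scatter) in this assay. Compound 4 is thus estimated at 620 nM, within 300 nM to 1300 nM.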

Compound 4, half-maximal inhibitory concentration: 1000 nM
The estimate for compound 4 lay 1.6-fold (0.21 log units) below the measured number; low and high end bracket the measured number.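

In this assay, placing the methyl on the benzyl arm of compound 3 gives a 2.1-fold higher number from compound 3 to compound 4 (0.33 log units; beyond the scatter), and this step does not differ reliably from the earlier one: the same change on two cores in this assay, a 1.4-fold higher number (0.14 log units; within the scatter) from compound 1 to compound 2 and a 2.1-fold higher number (0.33 log units; beyond the scatter) from compound 3 to compound 4, 1.5-fold (0.19 log units) apart, within the scatter of two such steps. The data therefore give no ground to say that the change acts differently on the two cores, although one step lies within the scatter and the other beyond it. Going by these compounds alone, this does not prove that the change carries over reliably, since there are only two pairs and the methyl enters at a different place in each; compound 4 also cannot be separated from the simpler amines, with a 1.0-fold higher number from compound 2 to compound 4 (0.00 log units; within the scatter) and a 1.4-fold higher number from compound 1 to compound 4 (0.14 log units; within the scatter).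

The compounds shown leave open how the mirror-image form of compound 4 would read in this assay. They also leave open what a tertiary amine, or a longer chain leading to the amine nitrogen, would do.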